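Larger Aryl Group Added to a Compound at the Limit

The source may report more compounds than this note shows. Statements on the series, on what has been measured and on what is new or still open speak of the compounds shown alone.

Compound 1 `Cc1c(O)ccc2cc(-n3cc(-c4ccc(F)cc4F)nn3)c(=O)oc12`: in a functional assay on MCF7 cells (Homo sapiens) for antiproliferative activity (a higher number here means a weaker inhibitor, a lower number a stronger inhibitor), compound 1 gives 33500 nM.
Compound 2 `COc1ccc(-c2cn(-c3cc4ccc(O)c(C)c4oc3=O)nn2)cc1`: compound 2 gives > 100000 nM, which is a limit of the assay and not a number.
Compound 3 `Cc1c(O)ccc2cc(-n3cc(-c4ccc(N(C)C)cc4)nn3)c(=O)oc12`: compound 3 gives > 100000 nM, likewise a limit.

Compound 2 therefore stands only at the assay's upper limit, and no number is known for it; of the three values, two sit at that limit, as the limit of > 100000 nM in this assay, at which 2 of the 3 values shown sit, records. Compound 4 `COc1cccc(-c2cc(-c3cn(-c4cc5ccc(O)c(C)c5oc4=O)nn3)ccc2OC)c1` differs from compound 2 in one place: 3-methoxyphenyl in place of hydrogen on an aromatic carbon. The measured steps all concern exchange of the aryl group on the shared core: an at least 2.9-fold higher number from compound 1 to compound 2 (0.47 log units; beyond the scatter) and an at least 2.9-fold higher number from compound 1 to compound 3 (0.47 log units; beyond the scatter), both toward weaker inhibition, while a step that the two limits leave unreadable from compound 2 to compound 3. None of them adds a further ring at the position changed here, so they say nothing about the size or direction of this step. Since the starting point is a limit, any change can only be guessed. Compound 4 is expected to give 100000 nM, with a range from 30000 nM to 300000 nM, most likely again reported as a limit. That estimate amounts to a number no higher from compound 2 to compound 4 (the limit leaves the size open), a step not expected to exceed the scatter.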

Compound 4, half-maximal inhibitory concentration: 28000 nM
For compound 4 the middle estimate is 3.6-fold (0.55 log units) above the measured one, outside the stated range (below it).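

In this assay, placing a 3-methoxyphenyl group on the aromatic ring, ortho to the methoxy group of compound 2, gives an at least 3.5-fold lower number from compound 2 to compound 4 (0.55 log units; beyond the scatter). Going by these compounds alone, the earlier steps only exchanged one aryl group for another and pointed toward weaker inhibition, so this is the first sign that a further ring at this position can go the other way, toward stronger inhibition. The true size of the gain stays unknown, and only its minimum can be read, since the starting point is not a number but the ceiling of the measurement: the limit of > 100000 nM in this assay, at which 2 of the 4 values shown sit.

The compounds shown do not separate the contribution of the added ring from that of the methoxy group it carries, and a plain phenyl ring, or an amine or a carboxylic acid in place of that methoxy group, would bear on this question. Within the data shown here, it also remains open whether the same added ring would lower the number on the aryl groups of compound 1 and compound 3, where the group it would join differs from the one in compound 2.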